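The source may report more compounds than this note shows. Statements on the series, on what has been measured and on what is new or still open speak of the compounds shown alone.

Of the compounds shown here, two built on one shared core have been measured in a functional assay on the whole organism (strain Kunming) for inhibition, with Mus musculus as the target, with a stated time of 1 h, at a dose of 40 mg/kg by the oral route; a lower number here means less inhibition, a higher number more inhibition at the dose given (going by the name of the read-out). Compound 1 `O=C(/C=C/c1ccccc1)c1ccc(N2CCN(c3ccccc3Cl)CC2)cc1` gives 4.71% in this assay. Compound 2 `O=C(/C=C/c1ccccc1)c1ccc(N2CCN(S(=O)(=O)c3ccc4ccccc4c3)CC2)cc1` gives 35% in this assay, the higher of the two numbers, with compound 1 standing a gap below it that lies beyond the scatter. Compound 3 `COc1ccc(S(=O)(=O)N2CCN(c3ccc(C(=O)/C=C/c4ccccc4)cc3)CC2)cc1OC` has not yet been measured. It differs from compound 2 in one place: 3,4-dimethoxyphenyl in place of naphthalen-2-yl on a sulfonyl sulfur. Within the data shown here, no measured pair shows what an exchange of this kind does on the sulfonyl sulfur, so the expected step of a number 7 percentage points lower from compound 2 to compound 3 (within the scatter) is estimated to be small, a slight drop or nothing beyond the scatter, as the rest of compound 2 is kept unchanged. Compound 3 is therefore estimated to give 28% in this assay, with a range from 10% to 45%.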

Compound 3, a percentage reported as inhibition, in the whole organism at one dose (the size of the read-out at that dose, not a potency): 55.5%
Compound 3: middle estimate off by 27.5 percentage points, on the low side, and the stated range ends below it.
By their numbers in this assay, from the lowest: compound 1; then compound 2; then compound 3.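

In this assay, the group on the sulfonyl sulfur proves able to change the result: 3,4-dimethoxyphenyl in place of naphthalen-2-yl gives a number 20.5 percentage points higher from compound 2 to compound 3 (beyond the scatter). Among these compounds, this is the first measured pair at this position, and it shows that one six-membered aromatic ring bearing the methoxy groups can stand there in place of the two rings of naphthalen-2-yl without a drop in this read-out. No evidence is available that accounts for the rise.

The single exchange removes a ring and adds the methoxy groups together, so the compounds shown leave open which of these changes goes with the higher number. Plain phenyl and 4-methoxyphenyl on the sulfonyl sulfur remain open as tests that would separate the two.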